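The compounds below may be only part of what the source reports. "The series", "measured", "known", "first", "only" and "open" are said of these compounds alone.

Compound 1 `CC1(C)[C@H]2CC[C@]1(C)N(Cc1cn(-c3cccc(F)c3)nn1)C(=O)C2` — 90 nM
Compound 2 `CC1(C)[C@H]2CC[C@]1(C)N(Cc1cn(-c3ccc(C#N)cc3)nn1)C(=O)C2` — 90 nM

In a functional assay on LoVo cells (Homo sapiens) for inhibition, read by MTT assay, with a stated time of 24 h (on this read-out higher numbers stand for weaker inhibition and lower numbers for stronger inhibition), compound 1 gives 90 nM, level with compound 2 at 90 nM. Compound 3 `CC1(C)[C@H]2CC[C@]1(C)N(Cc1cn(-c3cccc(Br)c3)nn1)C(=O)C2` differs from compound 1 by bromo in place of fluoro on an aromatic carbon. Within the data shown here, the one measured step, no change at the digits printed from compound 1 to compound 2 (within the scatter), swaps the whole substituent on that ring and stays within the scatter, so it bears only loosely on this halogen exchange; no step measures one halogen against another. Compound 3 is therefore expected near compound 1, at 90 nM with a range of 40 nM to 200 nM. That expected step, no change at the digits printed from compound 1 to compound 3 (within the scatter), lies within the scatter.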

Compound 3, half-maximal inhibitory concentration: 30 nM
The estimate for compound 3 lay 3.0-fold (0.48 log units) above the measured number, outside the stated range (below it).
By their numbers in this assay, from the lowest: compound 3; then compounds 1 and 2 (each within the scatter of the next).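

Among these compounds, with bromo in place of fluoro as the only change, this assay shows a 3.0-fold lower number from compound 1 to compound 3 (0.48 log units; beyond the scatter) and so the halogen on this aromatic carbon does register. Compound 3 also stands apart from the 4-cyanophenyl compound, with a 3.0-fold lower number from compound 2 to compound 3 (0.48 log units; beyond the scatter) where the earlier pair showed no separation. Nothing measured here explains the shift.

Going by these compounds, whether chloro or iodo at this place would fall with fluoro or with bromo stays open. So does whether a methoxy group or an amine there would keep the lower number.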